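The compounds below may be only part of what the source reports. "The series", "measured", "known", "first", "only" and "open" are said of these compounds alone.

Working notes on the series. Going by the values given here, compound 2 `CN1CCN(c2ccc(Nc3ncc4nc(Nc5ccc(F)cc5)n([C@@H]5CCNC5)c4n3)cc2)CC1` gives 300 nM in a functional assay on HCC827 cells (Homo sapiens) for antiproliferative activity, read by MTT assay, with a stated time of 72 h (a higher number here means a weaker inhibitor, a lower number a stronger inhibitor), the highest of the two numbers measured so far. Among the compounds with values here, its nearest neighbour is compound 1 `CN1CCN(c2ccc(Nc3ncc4nc(Nc5ccc(F)cc5)n([C@@H]5CCCNC5)c4n3)cc2)CC1`, which in this assay gives 120 nM; the single measured step is a 2.5-fold higher number from compound 1 to compound 2 (0.40 log units; beyond the scatter), a modest change that lies beyond the scatter.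

The next compound, compound 3 `CNC(=O)CN1CC[C@H](n2c(Nc3ccc(F)cc3)nc3cnc(Nc4ccc(N5CCN(C)CC5)cc4)nc32)C1`, differs from compound 2 in one place: 1-((methylcarbamoyl)methyl)pyrrolidin-3-yl in place of pyrrolidin-3-yl on an aromatic nitrogen. Within the data shown here, no measured pair changes the group on the ring nitrogen in this way; the only step recorded, from compound 1 to compound 2, alters the ring itself and so does not bear directly on this change. With nothing to anchor a direction, the expectation for compound 3 in this assay is a step of about no change at the digits printed from compound 2 to compound 3 (within the scatter), that is, no change beyond the scatter. Compound 3 is therefore estimated at 300 nM, within a range from 100 nM to 900 nM.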

Compound 3, half-maximal inhibitory concentration: 1520 nM
Compound 3: the middle estimate sits 5.1-fold (0.70 log units) below what was measured; measured number outside the range, above it.
By their numbers in this assay, from the lowest: compound 1; then compound 2; then compound 3.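

Putting a group on the ring nitrogen of the pyrrolidin-3-yl substituent changes the result in this assay, with the 1-((methylcarbamoyl)methyl)pyrrolidin-3-yl group giving a clear rise (a 5.1-fold higher number from compound 2 to compound 3 (0.70 log units; beyond the scatter)). Going by these compounds alone, measured against the piperidin-3-yl group, the same substituent gives a wider gap (a 13-fold higher number from compound 1 to compound 3 (1.10 log units; beyond the scatter)), which makes compound 3 the weakest of the three compounds so far. Nothing measured here accounts for this rise.

Still open, on these data alone, is whether the rise follows from any group on that ring nitrogen or specifically from the methylcarbamoyl end; a plain methyl, a 2-hydroxyethyl chain or a carboxylic acid in its place would separate these readings. Also open, as far as these compounds go, is how the (methylcarbamoyl)methyl group behaves on the ring nitrogen of the piperidin-3-yl substituent.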